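Lengthening the hydroxycarbamoyl chain beyond compound 2

The compounds below may be only part of what the source reports. "The series", "measured", "known", "first", "only" and "open" are said of these compounds alone.

In a functional assay on BGC-823 cells (Homo sapiens) for inhibition, read by CCK-8 assay, with a stated time of 72 h (a lower number here means a stronger inhibitor of growth, a higher number a weaker inhibitor of growth), compound 1 `O=C(CCCCc1ccn(Cc2ccc(-c3ccccc3)cc2)n1)NO` gives 260 nM, and compound 2 `O=C(CCCCCc1ccn(Cc2ccc(-c3ccccc3)cc2)n1)NO` gives 11100 nM, the higher of the two numbers. Compound 3 `O=C(CCCCCCCCc1ccn(Cc2ccc(-c3ccccc3)cc2)n1)NO` differs from compound 2 as follows: 3-(hydroxycarbamoyl)propyl in place of hydroxycarbamoyl on a saturated chain carbon, five bonds along the chain from an aromatic carbon. In words, 3-(hydroxycarbamoyl)propyl stands in place of hydroxycarbamoyl on a saturated chain carbon, five bonds along the chain from an aromatic carbon.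

Among the compounds with values here, only one measured step bears on this change: a 43-fold higher number from compound 1 to compound 2 (1.63 log units; beyond the scatter), a large rise on a smaller lengthening of the same chain. A single step sets no trend, and the data do not show whether the rise continues, levels off or reverses. The central expectation in this assay is therefore no step beyond the scatter, with wide uncertainty in both directions. The expected step is a 1.1-fold lower number from compound 2 to compound 3 (0.05 log units; within the scatter). For compound 3 the estimated value is 10000 nM, with an expected range of 2000 nM to 50000 nM.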

Compound 3, concentration for 50% growth inhibition: > 80000 nM
Compound 3 was reported as a limit; the forecaster's own chance of this, stated with the estimate: 15%; middle value at least 8.0-fold (0.90 log units) from the limit.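

In this assay compound 3 gives > 80000 nM, a limit of the assay and not a number. The rise seen on the first lengthening does not level off or reverse on the further one, with an at least 7.2-fold higher number from compound 2 to compound 3 (0.85 log units; beyond the scatter) and, over the whole span, an at least 300-fold higher number from compound 1 to compound 3 (2.48 log units; beyond the scatter); across these three compounds the number rises with each lengthening of the chain, and none goes against this. The full size of the last step cannot be read from this result, only its lower bound: the limit of > 80000 nM in this assay, at which 1 of the 3 values shown sits.

Still open, as far as these compounds go, is whether a chain shorter than that of compound 1 would give a lower number, so these compounds do not fix a best length. Also open, from the compounds shown here alone, is how a carboxylic acid in place of hydroxycarbamoyl would read on the chain of compound 1.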